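The compounds below may be only part of what the source reports. "The series", "measured", "known", "first", "only" and "open" are said of these compounds alone.

Measured so far:
- compound 1 `COc1ccc(/C=N/NC(=O)Nc2ccc(Oc3ccnc(-c4nncn4CCN(C)C)c3)c(F)c2)c(OC)c1`: 2820 nM
- compound 2 `CN(C)CCn1cnnc1-c1cc(Oc2ccc(NC(=O)N/N=C/c3ccc(F)cc3F)cc2F)ccn1`: 1870 nM
- compound 3 `CN(C)CCn1cnnc1-c1cc(Oc2ccc(NC(=O)N/N=C/c3cccc(Cl)c3Cl)cc2F)ccn1`: 1090 nM

In a functional assay on A549 cells (Homo sapiens) for cytotoxicity, read by MTT assay, with a stated time of 72 h (a higher number here means a weaker inhibitor, a lower number a stronger inhibitor), compound 1 gives 2820 nM, the highest of the three numbers. Compound 2 sits nearest to it, and a 1.5-fold lower number from compound 1 to compound 2 (0.18 log units; within the scatter) stays within the scatter; compound 3 lies furthest, and a 2.6-fold lower number from compound 1 to compound 3 (0.41 log units; beyond the scatter) is modest but beyond it. Compound 4 `CN(C)CCn1cnnc1-c1cc(Oc2ccc(NC(=O)N/N=C/c3ccc(O)cc3O)cc2F)ccn1` is not yet measured in this assay. Its change from compound 1 is 2,4-dihydroxyphenyl in place of 2,4-dimethoxyphenyl on a carbon with a double bond to nitrogen. Within the data shown here, the only steps that bear on it are those from compound 1 to compounds 2 and 3, both of which also exchange the 2,4-dimethoxyphenyl, and both gave lower numbers, one within and one just beyond the scatter. Among the measured compounds shown here, no measured step introduces a hydroxy-bearing ring, so the direction for compound 4 is uncertain. For compound 4 a step of about a 1.1-fold lower number from compound 1 to compound 4 (0.05 log units; within the scatter) is expected, not clearly beyond the scatter. Compound 4 is therefore estimated at 2500 nM, with a range from 900 nM to 7000 nM.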

Compound 4, half-maximal inhibitory concentration: 12700 nM
Estimate against measurement, compound 4: 5.1-fold (0.71 log units) below; the measured number lies above the stated range.
By their numbers in this assay, from the lowest: compounds 3, 2 and 1 (each within the scatter of the next, the first and the last beyond it); then compound 4.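

In this assay, the aryl group on the carbon with a double bond to nitrogen can also raise the number: 2,4-dihydroxyphenyl gives (a 4.5-fold higher number from compound 1 to compound 4 (0.65 log units; beyond the scatter)), and the direction is the same against the halogen-bearing rings (a 6.8-fold higher number from compound 2 to compound 4 (0.83 log units; beyond the scatter)) (a 12-fold higher number from compound 3 to compound 4 (1.07 log units; beyond the scatter)). Among these compounds, of the exchanges so far, only the one that enters hydrogen-bond donors gives a higher number, while the others give lower or scatter-level ones. No measurement at hand accounts for this. Open, from the compounds shown here alone, is whether a single hydroxy group behaves like compound 4, and whether a phenyl ring bearing an amine or a carboxylic acid does too.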